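The compounds below may be only part of what the source reports. "The series", "measured", "known", "first", "only" and "open" are said of these compounds alone.

Among the compounds with values here, in a functional assay on COLO 205 cells (Homo sapiens) for antiproliferative activity, read by sulforhodamine B assay, with a stated time of 48 h (a lower number here means a stronger inhibitor, a higher number a weaker inhibitor), compound 1 (`O=C(NCCCNc1cc(-c2cn(-c3ccccc3)nc2-c2cccc(O)c2)ccn1)Nc1ccc(F)cc1`) gives 2340 nM and compound 2 (`O=C(NCCCNc1cc(-c2cn(-c3ccccc3)nc2-c2cccc(O)c2)ccn1)Nc1cccc(C(F)(F)F)c1`) gives 2970 nM, so compound 1 stands within the scatter of its only measured neighbour. Compound 3 (`COc1cccc(-c2nn(-c3ccccc3)cc2-c2ccnc(NCCCNC(=O)Nc3ccc(F)cc3)c2)c1`) differs from compound 1 by methyl in place of hydrogen on an oxygen on an aromatic ring, turning hydroxy to methoxy. Within the data shown here, the one measured step, a 1.3-fold higher number from compound 1 to compound 2 (0.10 log units; within the scatter), lies on an amide-type nitrogen, so no measurement speaks directly to this oxygen. A small rise in this assay is therefore expected, possibly none beyond the scatter. Compound 3 is estimated at 3500 nM, with an expected range of 1300 nM to 9500 nM. The expected change is a 1.5-fold higher number from compound 1 to compound 3 (0.17 log units; within the scatter).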

Compound 3, half-maximal inhibitory concentration: 8170 nM
The estimate for compound 3 lay 2.3-fold (0.37 log units) below the measured number; low and high end bracket the measured number.
By their numbers in this assay, from the lowest: compounds 1 and 2 (each within the scatter of the next); then compound 3.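

In this assay the change from hydroxy to methoxy gives a 3.5-fold higher number from compound 1 to compound 3 (0.54 log units; beyond the scatter) and so moves the number beyond the scatter, whereas a 1.3-fold higher number from compound 1 to compound 2 (0.10 log units; within the scatter) on the amide-type nitrogen did not. This oxygen on the aromatic ring is thus the first place in the series shown where a single change separates two compounds, with the free hydroxy on the lower number. No evidence at hand accounts for the rise.

On these data alone, whether an amine, a fluorine or an ethoxy group in place of the hydroxy would behave like methoxy stays open. So does whether methoxy brings a similar rise when paired with the 3-(trifluoromethyl)phenyl group of compound 2.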